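A few compounds are considered here, and "the series" means these few. Any claim that something is new, unique, unknown or untested is made for them only; others in the source may bear on it.

Within the data shown here, three related compounds have numbers so far in a functional assay on OVCAR-8 cells (Homo sapiens) (on this read-out lower numbers stand for stronger inhibition of growth and higher numbers for weaker inhibition of growth), and compound 3 (`O=S(=O)(/C=C/c1ccc(Br)cc1)Cc1ccc(Nc2ncnc3ccc(Br)cc23)cc1`) stands lowest among them at 2000 nM while compound 2 (`CC(C)(C)c1cc(/C=C/S(=O)(=O)Cc2ccc(Nc3ncnc4ccccc34)cc2)cc(C(C)(C)C)c1O`) gives 5000 nM and compound 1 (`O=S(=O)(/C=C/c1ccc(Br)cc1)Cc1ccc(Nc2ncnc3ccccc23)cc1`) gives 38000 nM as the highest of the three.

The next compound to test is compound 4 (`O=S(=O)(/C=C/c1ccc(C(F)(F)F)cc1F)Cc1ccc(Nc2ncnc3ccc(Br)cc23)cc1`). It differs from compound 3 in one place, where 2-fluoro-4-(trifluoromethyl)phenyl takes the place of 4-bromophenyl on a double-bonded chain carbon bound to a double-bonded chain carbon (2-fluoro-4-(trifluoromethyl)phenyl in place of 4-bromophenyl on a double-bonded chain carbon bound to a double-bonded chain carbon).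

Among the measured compounds shown here, only one measured step involves compound 3, and it is large: bromo in place of hydrogen on an aromatic carbon gave a 19-fold lower number from compound 1 to compound 3 (1.28 log units; beyond the scatter) and this counts as well beyond the usual scatter. That step does not touch the group being exchanged now, and compound 4 keeps the bromo that compound 3 gained. For the measured compounds named here, no measured step changes the 4-bromophenyl group alone, so the data offer neither a size nor a direction for this exchange.

With no such evidence, no step beyond the scatter is expected in this assay and the estimated change is a 1.3-fold lower number from compound 3 to compound 4 (0.10 log units; within the scatter) with wide uncertainty on both sides. For compound 4 the estimated value is 1600 nM with 500 nM to 5500 nM as the expected range.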

Compound 4, concentration for 50% growth inhibition: 15000 nM
Compound 4: the middle estimate sits 9.4-fold (0.97 log units) below what was measured, and the stated range ends below it.
By their numbers in this assay, from the lowest: compound 3; then compound 2; then compound 4; then compound 1.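

The group on the double-bonded chain carbon is not a free place for exchange in this assay, as 2-fluoro-4-(trifluoromethyl)phenyl in place of 4-bromophenyl gives a 7.5-fold higher number from compound 3 to compound 4 (0.88 log units; beyond the scatter) and so weaker inhibition of growth. Keeping the bromo that came with a 19-fold lower number from compound 1 to compound 3 (1.28 log units; beyond the scatter) therefore does not hold the number low through every change at this other place. The exchange alters two things at once, adding a fluoro to the ring and putting trifluoromethyl where the bromo stood, and no measurement here explains the higher number.

The compounds shown leave open whether the fluoro, the trifluoromethyl or the two together account for the step, and a ring carrying only one of them would separate these cases. They also leave open how rings with other groups, such as a 4-chlorophenyl, a 4-methoxyphenyl or a phenyl bearing an amine, would behave at this place, and whether this exchange would give a step of similar size on the core of compound 1.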